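A few compounds are considered here, and "the series" means these few. Any claim that something is new, unique, unknown or untested is made for them only; others in the source may bear on it.

Compound 1 `C=CC(=O)Nc1cc2c(Nc3ccc(Oc4cc5nncn5cn4)c(C)c3)ncnc2cc1OCC`: 4.69 nM
Compound 2 `Cc1cc(Nc2ncnc3cc(O)c(NC(=O)/C=C/[C@H]4CCCN4C)cc23)ccc1Oc1cc2nccn2cn1`: 5.59 nM

In a functional assay on BT-474 cells (Homo sapiens) for inhibition, read by CellTiter-Glo, with a stated time of 72 h (on this read-out lower numbers stand for stronger inhibition and higher numbers for weaker inhibition), compound 2 gives 5.59 nM, which lies within the scatter of compound 1 at 4.69 nM. Compound 3 `Cc1cc(Nc2ncnc3cc(O)c(NC(=O)/C=C/[C@H]4CCCN4C)cc23)ccc1Oc1ccn2cnnc2c1` has the same atoms as compound 2, joined differently: a group of 9 heavy atoms (6 carbon, 3 nitrogen; one five-membered aromatic ring with 3 hetero atoms, one six-membered aromatic ring with 1 hetero atom) in place of a group of 9 heavy atoms (6 carbon, 3 nitrogen; one five-membered aromatic ring with 2 hetero atoms, one six-membered aromatic ring with 2 hetero atoms), on an oxygen on an aromatic ring. Among the compounds with values here, no measured pair shows the effect of such an exchange, so any forecast remains uncertain. A modest move towards weaker inhibition is expected, possibly no larger than the scatter, and the estimated change is a 1.4-fold higher number from compound 2 to compound 3 (0.16 log units; within the scatter). In this assay, the expected value for compound 3 is 8 nM, with an estimated range from 2.5 nM to 30 nM.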

Compound 3, half-maximal inhibitory concentration: 26.8 nM
For compound 3 the middle estimate is 3.4-fold (0.53 log units) below the measured one, within the range that was stated.
By their numbers in this assay, from the lowest: compounds 1 and 2 (each within the scatter of the next); then compound 3.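

In this assay, moving one nitrogen from the six-membered to the five-membered aromatic ring gives a 4.8-fold higher number from compound 2 to compound 3 (0.68 log units; beyond the scatter), a step beyond the scatter. The two groups have the same heavy atoms, the same hydrogen-bond counts and no net charge, so this place on an oxygen on an aromatic ring responds to how the atoms are joined, not only to which atoms are present. No available measurement explains this shift. As far as these compounds go, it remains open how a propyl chain or a carboxylic acid would behave in this place.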